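This account rests on a few compounds, and the source may have more. Where it says the series, first, only, none or still open, it means among the compounds named here.

Compound 1, `COc1ccc(C2CC(c3ccc(OC)c(OC)c3)=NN2C(=O)CBr)c(OC)c1`: 67%
Compound 2, `COc1ccc(C2=NN(C(=O)C(C)Br)C(c3ccco3)C2)cc1OC`: 36%

Going by the values given here, in a functional assay on the whole organism (strain albino) for inhibition, with Rattus norvegicus as the target, read by paw edema, with stated times of 30 min and 2 h, at a dose of 100 mg/kg by the oral route (on this read-out higher numbers stand for more inhibition at the one dose given (going by the name of the read-out) and lower numbers for less inhibition), compound 2 gives 36%, the lowest of the two numbers known, while compound 1 gives 67%, a gap beyond the usual scatter. Compound 3, `COc1ccc(C2CC(c3ccc(OC)c(OC)c3)=NN2C(=O)C(C)Br)c(OC)c1`, has not yet been measured. It differs from compound 2 in one place: 2,4-dimethoxyphenyl in place of furan-2-yl on a saturated ring carbon. Compound 3 thus carries the two methoxy-bearing phenyl groups of compound 1 together with the (1-bromoethyl)carbonyl group of compound 2. Among the compounds with values here, no measured pair isolates this single change, so the direction rests on compound 1 alone, which gives 67%. An upward step of a number 19 percentage points higher from compound 2 to compound 3 (beyond the scatter) is expected in this assay. Compound 3 is expected to give 55%, within a range from 35% to 75%.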

Compound 3, a percentage reported as inhibition, in the whole organism at one dose (the size of the read-out at that dose, not a potency): 63%
Compound 3: the middle estimate sits 8 percentage points below what was measured; the measured number falls inside the stated range.
By their numbers in this assay, from the lowest: compound 2; then compounds 3 and 1 (each within the scatter of the next).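

In this assay, 2,4-dimethoxyphenyl in place of furan-2-yl on the saturated ring carbon gives a number 27 percentage points higher from compound 2 to compound 3 (beyond the scatter) with the (1-bromoethyl)carbonyl group present, so the group at this position matters. Methyl in place of hydrogen on the chain carbon bound to bromine and the carbonyl carbon gives a number 4 percentage points lower from compound 1 to compound 3 (within the scatter) and so shows no clear change in this read-out. Nothing measured here explains either step.

The compounds shown leave open how a plain phenyl or a pyridine ring would behave at this ring carbon. They also leave open what an amine in place of the bromine would do.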